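This account rests on a few compounds, and the source may have more. Where it says the series, first, only, none or still open, it means among the compounds named here.

Compound 1 `COc1ccccc1-c1csc2cnc(Nc3ccc(NC(=O)CN)cc3)nc12` is one of three compounds tested in a functional assay on A549 cells (Homo sapiens) for inhibition, read by MTT assay, with a stated time of 72 h (a higher number here means a weaker inhibitor, a lower number a stronger inhibitor), where compound 1 gives 1950 nM. On the numbers in hand, compound 1 stands second highest: compound 2 `COc1ccccc1-c1csc2cnc(Nc3ccc(C(=O)NCC4CCNCC4)c(F)c3)nc12` gives 3410 nM, a value within the scatter of compound 1, while compound 3 `CNC(=O)c1ccc(Nc2ncc3scc(-c4ccccc4OC)c3n2)cc1` gives 310 nM, well clear of it. The step from compound 1 to compound 4 `COc1ccccc1-c1csc2cnc(Nc3ccc(C(=O)NC4CCNCC4)cc3)nc12` is (piperidin-4-yl)carbamoyl in place of ((aminomethyl)carbonyl)amino on an aromatic carbon. Within the data shown here, one measured step bears on it: a 6.3-fold lower number from compound 1 to compound 3 (0.80 log units; beyond the scatter), in which a carbamoyl group likewise replaced the ((aminomethyl)carbonyl)amino group on the same aromatic carbon. Compound 2 carries a related carbamoyl group but with an added fluorine, so no single-change comparison with compound 1 exists; its value simply sits near that of compound 1. Because of a 6.3-fold lower number from compound 1 to compound 3 (0.80 log units; beyond the scatter), compound 4 is expected to show a lower number than compound 1, though a (piperidin-4-yl)carbamoyl group is larger than methylcarbamoyl, so the expected step of a 2.4-fold lower number from compound 1 to compound 4 (0.39 log units; beyond the scatter) is taken as smaller. Compound 4 is therefore estimated at 800 nM, within a range of 250 nM to 2500 nM.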

Compound 4, half-maximal inhibitory concentration: 360 nM
Compound 4: the middle estimate sits 2.2-fold (0.35 log units) above what was measured; the measured number falls inside the stated range.
By their numbers in this assay, from the lowest: compounds 3 and 4 (each within the scatter of the next); then compounds 1 and 2 (each within the scatter of the next).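

With a second carbamoyl group now at this aromatic carbon, the gain over the ((aminomethyl)carbonyl)amino group of compound 1 no longer rests on methylcarbamoyl alone: (piperidin-4-yl)carbamoyl also gives a step beyond the scatter (a 5.4-fold lower number from compound 1 to compound 4 (0.73 log units; beyond the scatter)) in this assay. Piperidin-4-yl in place of methyl on the amide-type nitrogen gives no readable difference (a 1.2-fold higher number from compound 3 to compound 4 (0.06 log units; within the scatter)), so this six-membered non-aromatic ring is accommodated on that nitrogen in this assay. No measurement shown accounts for either step. The compounds shown leave open whether the ring nitrogen of piperidin-4-yl contributes anything, which a cyclohexyl group on the same amide nitrogen would address. They also leave open how far this tolerance extends, for instance to a longer chain ending in an amine or to a carboxylic acid.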